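A few compounds are considered here, and "the series" means these few. Any claim that something is new, unique, unknown or untested is made for them only; others in the source may bear on it.

Three compounds have results so far in a functional assay on MDA-MB-231 cells (Homo sapiens) for antiproliferative activity, read by MTT assay, with a stated time of 24 h (on this read-out lower numbers stand for stronger inhibition and higher numbers for weaker inhibition), and a fourth awaits measurement. Compound 1 `Cc1ccccc1NNC(=O)c1ccc(NS(=O)(=O)c2cnc(O)nc2O)cc1` reads > 20000 nM there, which is a limit of the assay and not a number. Compound 2 `O=C(NNc1ccccc1Cl)c1ccccc1NS(=O)(=O)c1cnc(O)nc1O` gives 18900 nM as the higher of the two true numbers available. Compound 3 `O=C(NNC(=O)c1ccccc1Cl)c1cccc(NS(=O)(=O)c2cnc(O)nc2O)c1` gives 2360 nM as the lower one, and the gap between these two numbers lies beyond the usual scatter.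

Compound 4 `O=C(NNC(=O)c1ccccc1NS(=O)(=O)c1cnc(O)nc1O)c1ccccc1Cl` has not yet been measured. It departs from compound 2 through (2-chlorophenyl)carbonyl in place of 2-chlorophenyl on an amine nitrogen and so turns (2-chlorophenyl)amino into ((2-chlorophenyl)carbonyl)amino. Among the measured compounds shown here, no measured pair isolates this change. The nearest guide is compound 3 at 2360 nM as it also carries the ((2-chlorophenyl)carbonyl)amino group, but it differs from compound 2 elsewhere as well, so only part of its lower number is expected to carry over. The expected step of a 3.2-fold lower number from compound 2 to compound 4 (0.50 log units; beyond the scatter) is toward a lower number and stronger inhibition, modestly beyond the scatter. For compound 4 the estimated value is 6000 nM with an expected range from 1800 nM to 20000 nM in this assay once it is tested.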

Compound 4, half-maximal inhibitory concentration: 8310 nM
For compound 4 the middle estimate is 1.4-fold (0.14 log units) below the measured one; the range from low to high includes it.
By their numbers in this assay, from the lowest: compound 3; then compound 4; then compound 2. At a limit, above all of these: compound 1.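

For the first time among the compounds shown, one change stands alone: in this assay, (2-chlorophenyl)carbonyl in place of 2-chlorophenyl on an amine nitrogen gives a 2.3-fold lower number from compound 2 to compound 4 (0.36 log units; beyond the scatter), a modest step toward stronger inhibition. The aromatic ring and the chlorine are present on both sides of this change, and what is added is a carbonyl with its hydrogen-bond acceptor, although the result does not show which feature of the carbonyl lies behind the step. Compound 4 shares the ((2-chlorophenyl)carbonyl)amino group with compound 3, yet compound 4 reads 8310 nM while compound 3 reads 2360 nM, so this group alone does not bring the lower number of compound 3.

Among the compounds shown here, compound 1 remains a limit and not a number, so it sets the size of no step: the limit of > 20000 nM in this assay, at which 1 of the 4 values shown sits. It remains open how an acetyl group or a pyridine-3-carbonyl group would read in place of (2-chlorophenyl)carbonyl on the same amine nitrogen, and whether the step seen here would hold with a different group on the rest of the molecule.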